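From hydroxymethyl to formyl at the assay limit

The source may hold more compounds than are shown below. What is called first, only, known or untested is meant among the compounds shown, and "the series" means these compounds.

In a functional assay on HT-1080 cells (Homo sapiens) for antiproliferative activity, read by MTT assay, with a stated time of 72 h (a lower number here means a stronger inhibitor, a higher number a weaker inhibitor), compound 1 (`C=C1CC[C@H]2O[C@@]2(C)[C@H](OC(=O)C=C(C)C)/C=C/[C@@](C)(CCC=C(C)C)C[C@H]1O`) gives > 20000 nM, which is a limit of the assay.

Compound 2 (`CC(C)=CCC[C@]1(C)/C=C/[C@@H](OC(=O)C=C(C)C)[C@]2(C)O[C@@H]2CC/C(CO)=C\C1`) gives > 20000 nM, also a limit, so its true position is not known.

Compound 3 (`CC(C)=CCC[C@]1(C)/C=C/[C@@H](OC(=O)C=C(C)C)[C@]2(C)O[C@@H]2CC/C(C=O)=C\C1`) follows from compound 2 by formyl in place of hydroxymethyl on a double-bonded ring carbon.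

Going by the values given here, no measured step guides the expectation.

A modest expected move toward a stronger inhibitor is an at least 1.6-fold lower number from compound 2 to compound 3 (0.22 log units; that floor lies within the scatter), and a result again at the limit in this assay would be no surprise.

Compound 3 is estimated at 12000 nM, with an expected range of 4000 nM to 30000 nM.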

Compound 3, half-maximal inhibitory concentration: 18000 nM
Beside the measured number, compound 3's estimate is 1.5-fold (0.18 log units) below it, within the range that was stated.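

In this assay, going by these compounds alone, formyl on the double-bonded ring carbon gives the first value of the series that is not a limit, so this position admits a change that yields a number. The step reads as an at least 1.1-fold lower number from compound 2 to compound 3 (0.04 log units; that floor lies within the scatter) and only that floor can be taken from it. Its true size stays unknown because compound 2 carries only a limit: the limit of > 20000 nM in this assay, at which 2 of the 3 values shown sit.

Going by these compounds, whether a carboxylic acid, an amine or a longer chain on this ring carbon would lower the number further stays open. Also open, on these data alone, is whether formyl is needed here or other replacements of hydroxymethyl would serve equally.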